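Dropping the Chloro Group from Compound 1

A few compounds are considered here, and "the series" means these few. Any claim that something is new, unique, unknown or untested is made for them only; others in the source may bear on it.

Compound 1: `O=c1c(C(=S)Nc2ccccc2)coc2cc(Cl)ccc12` gives > 100000 nM in a functional assay on OVCAR-3 cells (Homo sapiens) for inhibition, read by sulforhodamine B assay, with a stated time of 48 h (a lower number here means a stronger inhibitor, a higher number a weaker inhibitor), a limit of the assay rather than a number.
Compound 2: `O=c1c(C(=S)Nc2ccccc2)coc2cc(Cl)c(Cl)cc12` gives > 100000 nM, again a limit.
Compound 3: `O=c1c(C2N=C(c3ccccc3)SS2)coc2cc(Cl)ccc12` gives 10500 nM.

Compound 1 therefore sits at the limit of > 100000 nM in this assay, at which 2 of the 3 values shown sit, and is not placed as a number. Among the compounds with values here, the only single-change step among the measured compounds, a step that the two limits leave unreadable from compound 1 to compound 2, adds a second chloro to compound 1, and both ends are limits, so its size cannot be read. Within the data shown here, compound 3 carries a different group on the shared core and is the one measured compound with a numerical value, but it differs from compound 1 in a way that no step describes, so only its value is known.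

Compound 4, `O=c1c(C(=S)Nc2ccccc2)coc2ccccc12`, differs from compound 1 by hydrogen in place of chloro on an aromatic carbon. Among the measured compounds shown here, no measured step bears directly on this change, and the measured step from a chloro addition is unreadable. The expectation for compound 4 is thus shaped mainly by the limit of compound 1: a step of a number no higher from compound 1 to compound 4 (the limit leaves the size open) in this assay is expected, that is, none that can be shown beyond the scatter. Compound 4 is estimated at 100000 nM, between 30000 nM and 300000 nM, most likely reported again as a limit.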

Compound 4, half-maximal inhibitory concentration: 86400 nM
The estimate for compound 4 lay 1.2-fold (0.06 log units) above the measured number; the range from low to high includes it.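

Taking the chloro away gives a first reading for this place on the aromatic ring: in this assay, hydrogen in place of chloro gives an at least 1.1-fold lower number from compound 1 to compound 4 (0.06 log units; that floor lies within the scatter). At this place, the change therefore shows no loss of inhibition, while any gain that can be shown from these values stays within the scatter, so the chloro is not shown to be needed for the activity seen here. Compound 1 remains a limit rather than a number, so only the floor of the step can be read and its true size may be larger: the limit of > 100000 nM in this assay, at which 2 of the 4 values shown sit.

The step that adds a second chloro has limits at both ends and cannot be read, so the compounds shown give no readable effect of adding chloro to this side of the shared core. Going by these compounds, whether a methoxy group, an amine or a carboxylic acid at this place would move the number clearly beyond the scatter stays open, as does whether removing the chloro would have any similar result on compound 3, with its different group on the shared core.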